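A few compounds are considered here, and "the series" means these few. Any claim that something is new, unique, unknown or untested is made for them only; others in the source may bear on it.

Measured so far in an ADME assay on cells (Hepatocyte, Rattus norvegicus) for metabolic stability; on this read-out higher numbers stand for fast clearance and lower numbers for slow clearance:
compound 1 `COc1cc(C(=O)N2CCCC2)ccc1-c1ccnc2[nH]c(C3CCOCC3)cc12` gives 15 uL/min
compound 2 `CN(C)C(=O)CN1CCC(c2cc3c(-c4ccc(=O)n(C5CCOCC5)c4)ccnc3[nH]2)CC1` gives 2.3 uL/min

Compound 2 stands lowest of the two numbers; compound 1 sits clearly higher, a gap beyond the usual scatter of this assay. Going by the values given here, no single-change step between measured compounds is available, so nothing is known from data about how the change at hand plays out.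

Compound 3 `CN(C)C(=O)CN1CCC(c2cc3c(-c4ccc(=O)n(C)c4)ccnc3[nH]2)CC1` differs from compound 2 by methyl in place of oxan-4-yl on an aromatic nitrogen. Among the compounds with values here, with no precedent, the step of a 1.1-fold higher number from compound 2 to compound 3 (0.04 log units; within the scatter) is expected to be small, likely within the scatter, with no clear direction. Compound 3 is therefore expected near 2.5 uL/min, in the range 1 uL/min to 6 uL/min.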

Compound 3, intrinsic clearance in a liver preparation (reported as CLH), per the amount of preparation that the assay uses: < 1 uL/min
Compound 3: no number, only a limit (the forecaster's own chance of this, stated with the estimate: 15%); middle value at least 2.5-fold (0.39 log units) away from the limit.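

On the aromatic nitrogen, methyl in place of oxan-4-yl is not a neutral change in this assay: it gives an at least 2.3-fold lower number from compound 2 to compound 3 (0.36 log units; beyond the scatter). The group on this nitrogen therefore bears on clearance in this pair, with methyl on the slow side. The full size of the step cannot be read, because compound 3 sits at a limit of the assay and not at a number: the limit of < 1 uL/min in this assay, at which 1 of the 3 values shown sits.

Only methyl and oxan-4-yl are shown on this nitrogen, so where an ethyl or a cyclopropyl group would fall remains open. Whether the step carries over to other substituents on the shared core also rests on this single pair.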